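The source may hold more compounds than are shown below. What is called first, only, known or untested is meant among the compounds shown, and "the series" means these compounds.

The series shares one core, carried by compound 1 `COc1ccc(CNC(=O)c2cc(-c3cc(C)cc(C)c3)cnc2-c2cccnc2)cc1OC`, compound 2 `COc1ccc(CNC(=O)c2cc(-c3cc(F)cc(F)c3)cnc2-c2cccnc2)cc1OC` and compound 3 `COc1ccc(CNC(=O)c2cc(-c3cc(C(F)(F)F)cc(C(F)(F)F)c3)cnc2-c2cccnc2)cc1OC`. In an assay on isolated protein for displacement of a labelled ligand from Orexin receptor type 2 (Homo sapiens), read by scintillation counting, with a stated time of 60 min (a lower number here means a stronger inhibitor, a higher number a weaker inhibitor), compound 1 gives 0.7 nM, compound 2 gives 8.3 nM and compound 3 gives 121 nM. Compound 2 therefore holds the second highest of the three numbers: its nearest neighbour is compound 1, with a lower number, and the furthest is compound 3, with a higher one. Compound 4 `COc1ccc(CNC(=O)c2cc(-c3cccc(Cl)c3)cnc2-c2cccnc2)cc1OC` has not been measured. It differs from compound 2 by 3-chlorophenyl in place of 3,5-difluorophenyl on an aromatic carbon, the 3-chlorophenyl standing on an aromatic carbon two atoms from the ring nitrogen, para to a pyridin-3-yl group. Within the data shown here, the one measured step that touches this place is a 12-fold higher number from compound 1 to compound 2 (1.07 log units; beyond the scatter), a large step, and compound 3 shows a still higher number at the same place. These data fix no direction for a single chloro, so compound 4 is expected to show only a modest step, a 2.8-fold lower number from compound 2 to compound 4 (0.44 log units; beyond the scatter), downward. Compound 4 is thus estimated at 3 nM, within a range from 0.7 nM to 15 nM in this assay.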

Compound 4, inhibition constant: 1.3 nM
Compound 4: the middle estimate sits 2.3-fold (0.36 log units) above what was measured, and the stated range covers the measured number.
By their numbers in this assay, from the lowest: compounds 1 and 4 (each within the scatter of the next); then compound 2; then compound 3.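

The move to 3-chlorophenyl brings a clear drop in this assay (a 6.4-fold lower number from compound 2 to compound 4 (0.81 log units; beyond the scatter)), so a ring with one substituent can hold a low number at this position, which compounds 1, 2 and 3, all with two identical substituents on the ring, could not show. Set against the 3,5-dimethylphenyl ring, the same change gives a 1.9-fold higher number from compound 1 to compound 4 (0.27 log units; within the scatter), so compound 1 and compound 4 cannot be told apart here, and the second substituent is not required for a number at this level. Nothing in the data accounts for these differences.

The compounds shown do not separate the effect of the chlorine atom from that of removing the second substituent, as a 3-fluorophenyl or 3-methylphenyl ring would. Nor do they show how this position responds to a ring carrying an amine or a carboxylic acid.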